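Substituents on the ring nitrogen: a T-cell inhibition series

This account rests on a few compounds, and the source may have more. Where it says the series, first, only, none or still open, it means among the compounds named here.

Measured compounds:
compound 1 `COc1ccc(-c2cnc3nc(N)nc(N4CCN(C(=O)Nc5ccc(C)cc5)CC4)c3n2)cc1OC` — 0.8 nM
compound 2 `COc1ccc(-c2cnc3nc(N)nc(N4CCN(C(=O)c5ccccc5)CC4)c3n2)cc1OC` — 400 nM
compound 3 `COc1ccc(-c2cnc3nc(N)nc(N4CCN(c5cc(Cl)cc(Cl)c5)CC4)c3n2)cc1OC` — 3400 nM

In a functional assay on cells (T-cell, Homo sapiens) for inhibition (a lower number here means a stronger inhibitor, a higher number a weaker inhibitor), compound 3 stands at the highest number of the three; compound 2 is nearest, showing an 8.5-fold higher number from compound 2 to compound 3 (0.93 log units; beyond the scatter), and compound 1 is furthest, showing a 4300-fold higher number from compound 1 to compound 3 (3.63 log units; beyond the scatter). Compound 4 `COc1ccc(-c2cnc3nc(N)nc(N4CCN(c5ccc(C)cc5)CC4)c3n2)cc1OC` differs from compound 3 by 4-methylphenyl in place of 3,5-dichlorophenyl on an amine nitrogen in a ring. For the measured compounds named here, no measured step exchanges one aryl group for another on that ring nitrogen; the only step at that position shows an 8.5-fold higher number from compound 2 to compound 3 (0.93 log units; beyond the scatter), a modest one. Compound 1 carries its 4-methylphenyl on a carbamoyl, a different attachment, so a 4300-fold higher number from compound 1 to compound 3 (3.63 log units; beyond the scatter) does not read across to this change. For compound 4 a modest step in either direction is expected, a 1.7-fold lower number from compound 3 to compound 4 (0.23 log units; within the scatter), and the estimate is 2000 nM within 500 nM to 8000 nM.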

Compound 4, half-maximal inhibitory concentration: 300 nM
Compound 4: the middle estimate sits 6.7-fold (0.82 log units) above what was measured, outside the stated range (below it).
By their numbers in this assay, from the lowest: compound 1; then compounds 4 and 2 (each within the scatter of the next); then compound 3.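

In this assay, for the compounds shown here, the aryl group on the ring nitrogen proves to matter, with the first aryl-for-aryl exchange at this position giving an 11-fold lower number from compound 3 to compound 4 (1.05 log units; beyond the scatter). Replacing benzoyl with 4-methylphenyl at the same nitrogen gives a 1.3-fold lower number from compound 2 to compound 4 (0.12 log units; within the scatter), so these two groups are not separated here. The 4-methylphenyl group alone does not reproduce the value of compound 1, given a 380-fold higher number from compound 1 to compound 4 (2.57 log units; beyond the scatter), so its carbamoyl attachment counts in this comparison.

No data at hand explain the aryl exchange. From the compounds shown here alone, whether losing the two chlorines or gaining the methyl drives it remains open, as does how a 4-methoxyphenyl or pyridine ring on that nitrogen would read.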